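This account rests on a few compounds, and the source may have more. Where it says the series, first, only, none or still open, it means among the compounds named here.

Going by the values given here, compound 3 `CC[C@H](C)[C@H](N)CN(C(=O)[C@@H]1C[C@H]1c1ccccc1)c1ccc(-c2ccc(CO)cc2)cc1` is, among the compounds with a single number in a functional assay for agonist activity at G protein-coupled receptor 88 (Homo sapiens), read by HTRF and cAMP accumulation (on this read-out higher numbers stand for an effect only at larger amounts of compound and lower numbers for an effect already at smaller amounts), the one giving the highest value: in this assay compound 3 gives 1100 nM. Among the compounds with values here, its nearest neighbour is compound 2 `CCc1ccc(-c2ccc(N(C[C@@H](N)[C@@H](C)CC)C(=O)[C@@H]3C[C@H]3c3ccccc3)cc2)cc1`, which in this assay gives 44 nM; the change a 25-fold higher number from compound 2 to compound 3 (1.40 log units; beyond the scatter) is the only measured step in this set. Compound 1 `CC[C@H](C)[C@H](N)CN(C(=O)[C@@H]1C[C@H]1c1ccccc1)c1ccc(-c2ccccc2)cc1`, which carries neither group on the outer ring, has been run more than once; in this assay compound 1 gives 230 nM; 800 nM (2 entries), as recorded in the several entries of compound 1 in this assay, 230 nM; 800 nM (2 entries).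

Compound 4 `CC[C@H](C)[C@H](N)CN(C(=O)[C@@H]1C[C@H]1c1ccccc1)c1ccc(-c2ccc(CNC)cc2)cc1` differs from compound 3 by methylamino in place of hydroxy on a saturated chain carbon bound to an aromatic carbon. Within the data shown here, no measured step exchanges a hydroxy for a methylamino, so the step from compound 2 to compound 3 bears on it only in that both compounds 1 and 3 lie well away from compound 2. Compound 4 is therefore expected to stay near the values of compounds 1 and 3, with an estimated step of a 1.4-fold lower number from compound 3 to compound 4 (0.14 log units; within the scatter). For compound 4 the estimated value in this assay is 800 nM, within a range from 200 nM to 4000 nM.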

Compound 4, half-maximal effective concentration: 6400 nM
Compound 4: the middle estimate sits 8.0-fold (0.90 log units) below what was measured, and the stated range ends below it.
By their numbers in this assay, from the lowest: compound 2; then compound 3; then compound 4.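

In this assay, the saturated chain carbon bound to an aromatic carbon proves sensitive even to an exchange that leaves the count of hydrogen-bond donors and acceptors unchanged: methylamino in place of hydroxy gives a 5.8-fold higher number from compound 3 to compound 4 (0.76 log units; beyond the scatter). Measured against methyl at the same place, methylamino gives a 150-fold higher number from compound 2 to compound 4 (2.16 log units; beyond the scatter), a larger step than the one hydroxy gave, so the numbers for these three groups rise from methyl through hydroxy to methylamino. The step from hydroxy to methylamino is only modest, and single entries for one compound can themselves lie well apart: the several entries of compound 1 in this assay, 230 nM; 800 nM (2 entries)

On these data alone, what a primary amine or a methoxy group would give at this place remains open, and with it whether the nitrogen or its added methyl carries the change. As far as these compounds go, how a carboxylic acid or a longer chain would read there is equally open.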